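Swapping an Azido-Hydroxy Chain for a Cyanobenzyl Group

This account rests on a few compounds, and the source may have more. Where it says the series, first, only, none or still open, it means among the compounds named here.

Measured so far:
Compound 1, `C=CCn1c(=S)n(C2OC(COCc3ccccc3)[C@H]3OC(C)(C)O[C@@H]23)c2nc(N)nc(O)c21`, gives 77% in a functional assay on the whole organism (B cells) with Mus musculus as the target; on this read-out higher numbers stand for larger maximal responses and lower numbers for smaller maximal responses.
Compound 2, `[N-]=[N+]=NCC(O)Cn1c(=O)n(C2OC(CO)[C@@H](O)[C@H]2O)c2nc(N)nc(O)c21`, gives 91%.

Compound 2 shows the higher maximal response of the two, and compound 1 sits lower by a margin beyond the usual scatter. Among the measured compounds shown here, no two measured compounds differ in only one place, so no single-change step is available as a guide. Compound 3, `N#Cc1cccc(Cn2c(=O)n(C3OC(CO)[C@@H](O)[C@H]3O)c3nc(N)nc(O)c32)c1`, differs from compound 2 by 3-cyanophenyl in place of 2-azido-1-hydroxyethyl on a saturated chain carbon bound to an aromatic nitrogen. Without a comparable step to lean on, a modest drop in this assay seems the more likely outcome, though a change within the scatter cannot be ruled out. The step expected here is a number 11 percentage points lower from compound 2 to compound 3 (beyond the scatter). Compound 3 is expected to give about 80%, between 60% and 100%.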

Compound 3, largest response reached (reported as maximal response), in percent of the reference or control that the assay uses: 16%
The estimate for compound 3 lay 64 percentage points above the measured number; measured number below the stated range.
By their numbers in this assay, from the lowest: compound 3; then compound 1; then compound 2.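

Among the compounds shown here, the first single-place change shows that the group on the saturated chain carbon bound to an aromatic nitrogen strongly affects the read-out: in this assay, 3-cyanophenyl in place of 2-azido-1-hydroxyethyl gives a number 75 percentage points lower from compound 2 to compound 3 (beyond the scatter). This is a large loss of maximal response from one substitution on an otherwise shared core. No available data explain the drop.

These compounds cannot separate losing the azido or hydroxyl group from gaining the cyanophenyl ring. An unsubstituted benzyl group or a simple hydroxypropyl chain at this place remains an open comparison.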